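A few compounds are considered here, and "the series" means these few. Any claim that something is new, unique, unknown or untested is made for them only; others in the source may bear on it.

Measured so far:
compound 1 `COc1ccc2c(OCCn3c(=O)oc4ccc(F)cc43)ccnc2c1`: > 500 nM
compound 2 `COC(=O)c1ccc2c(c1)oc(=O)n2CCOc1ccnc2cc(OC)ccc12`: > 500 nM

In a functional assay on EBC-1 cells (Homo sapiens) for inhibition, read by sulforhodamine B assay, with a stated time of 72 h (on this read-out higher numbers stand for weaker inhibition and lower numbers for stronger inhibition), compound 2 reaches only a limit, > 500 nM. Compound 1 likewise stops at a limit, > 500 nM. Both results sit at the limit of > 500 nM in this assay, at which 2 of the 2 values shown sit, so compound 2 cannot be placed above or below compound 1 on these numbers. Compound 3 `COc1ccc2c(OCCn3c(=O)oc4cc(-c5cnn(C)c5)ccc43)ccnc2c1` differs from compound 2 by 1-methyl-1H-pyrazol-4-yl in place of methoxycarbonyl on an aromatic carbon. Within the data shown here, no measured step of this kind is available, so the expectation rests on the change alone. Compound 3 is expected to inhibit more strongly, an estimated step of an at least 3.3-fold lower number from compound 2 to compound 3 (0.52 log units; beyond the scatter). Compound 3 is estimated at 150 nM, within a range from 20 nM to 2000 nM.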

Compound 3, half-maximal inhibitory concentration: 100 nM
Compound 3: the middle estimate sits 1.5-fold (0.18 log units) above what was measured; the range from low to high includes it.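

Putting 1-methyl-1H-pyrazol-4-yl in place of methoxycarbonyl on this aromatic carbon gives an at least 5.0-fold lower number from compound 2 to compound 3 (0.69 log units; beyond the scatter), so a change at this one position can bring a compound within the measurable range of the assay. Among these compounds, compound 3 is the first compound here with a true number rather than a limit. The step is only a minimum, and its full size stays unknown because compound 2 gives a limit: the limit of > 500 nM in this assay, at which 2 of the 3 values shown sit.

The compounds shown leave open whether the five-membered ring or its methyl carries the change. From the compounds shown here alone, how an amine or a carboxylic acid on this carbon would compare also remains open.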